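This account rests on a few compounds, and the source may have more. Where it says the series, first, only, none or still open, it means among the compounds named here.

Compound 1 `COc1cc2occ(-c3csc4ccccc34)c(=O)c2c(OC)c1OC` gives 820 nM in a functional assay on KB cells (Homo sapiens) for antiproliferative activity, read by sulforhodamine B assay, with a stated time of 72 h; on this read-out lower numbers stand for stronger inhibition and higher numbers for weaker inhibition. Compound 2 `COc1cc2occ(-c3csc4ccccc34)c(=O)c2c(OC)c1O` reaches only the limit > 10000 nM in this assay, a limit and not a number (the limit of > 10000 nM in this assay, at which 1 of the 3 values shown sits). Between them stands (methyl in place of hydrogen on an oxygen on an aromatic ring), which brings an at least 12-fold lower number from compound 2 to compound 1 (1.08 log units; beyond the scatter). Compound 3 `COc1ccc(O)c(C(=O)/C=C/c2csc3ccccc23)c1` gives 640 nM in this assay; how the core of compound 3 differs from the core of compound 2 is not broken down here. Compound 4 `COc1ccc(OC)c(C(=O)/C=C/c2csc3ccccc23)c1` carries methyl in place of hydrogen on an oxygen on an aromatic ring, the same change at the same kind of place as from compound 2 to compound 1. Since compound 1 and compound 3 sit within the scatter of each other, the step on the new core is expected to point the same way while staying smaller and uncertain, estimated at about a 1.8-fold lower number from compound 3 to compound 4 (0.26 log units; within the scatter). Compound 4 is thus estimated at 350 nM, with a range from 80 nM to 1500 nM.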

Compound 4, half-maximal inhibitory concentration: 4600 nM
Compound 4: the middle estimate sits 13-fold (1.12 log units) below what was measured, outside the stated range (above it).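

In this assay, hydroxy to methoxy on the core of compound 3 brings a 7.2-fold higher number from compound 3 to compound 4 (0.86 log units; beyond the scatter), so the change does not carry over with its direction kept: the same change on two cores in this assay, an at least 12-fold lower number (1.08 log units; beyond the scatter) from compound 2 to compound 1 and a 7.2-fold higher number (0.86 log units; beyond the scatter) from compound 3 to compound 4, at least 87-fold (1.94 log units) apart, beyond the scatter of two such steps. Compound 2 gives > 10000 nM, a limit and not a number. The two cores show only that the outcome of this change depends on the core in this series; they do not show which part of the core decides it, or why the direction reverses.

Open, on these data alone, is whether groups other than hydroxy and methoxy, such as a longer chain on that oxygen or an amine on the ring, would follow either direction. Also open, as far as these compounds go, is which direction a third core would take.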